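Trifluoromethyl to Nitro: Antiproliferative Activity Across Two Cores

This account rests on a few compounds, and the source may have more. Where it says the series, first, only, none or still open, it means among the compounds named here.

Compound 1 `FC(F)(F)c1ccc(COc2ccccc2Nc2ncnc3cc4c(cc23)OCCOCCO4)cc1` gives > 100000 nM in a functional assay on MCF7 cells (Homo sapiens) for antiproliferative activity, read by MTT assay, with a stated time of 72 h (a higher number here means a weaker inhibitor, a lower number a stronger inhibitor), a limit of the assay and not a number.
Compound 2 `FC(F)(F)c1ccc(COc2ccc(Nc3ncnc4cc5c(cc34)OCCOCCOCCOCCO5)cc2)cc1` gives 10000 nM in this assay.
Compound 3 `O=[N+]([O-])c1ccc(COc2ccc(Nc3ncnc4cc5c(cc34)OCCOCCOCCOCCO5)cc2)cc1` gives > 100000 nM in this assay, again a limit of the assay and not a number.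

Compounds 2 and 3 share one core and differ in a single place: nitro in place of trifluoromethyl on an aromatic carbon. That change weakened activity, as an at least 10-fold higher number from compound 2 to compound 3 (1.00 log units; beyond the scatter) shows. Compound 1 carries a different core; the difference between the two cores is not broken down here, and because compound 1 sits at the limit of > 100000 nM in this assay, at which 2 of the 3 values shown sit, there is no number to compare with compound 2.

The unmeasured compound 4 `O=[N+]([O-])c1ccc(COc2ccccc2Nc2ncnc3cc4c(cc23)OCCOCCO4)cc1` is made from compound 1 by the same change: nitro in place of trifluoromethyl on an aromatic carbon. The surroundings of the change are the same in words for both pairs, so it is the same change, made on a different core.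

What to expect for compound 4 rests on two things: the change weakened activity from compound 2 to compound 3, and compound 1 already gives only a limit. Compound 4 is therefore expected to show no measurable activity either, a step of roughly a step that the limit leaves unreadable from compound 1 to compound 4 from compound 1. The estimate for compound 4 in this assay is 300000 nM, with a range from 100000 nM to 3000000 nM, and most likely the assay will report only a limit.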

Compound 4, half-maximal inhibitory concentration: > 100000 nM
Compound 4 gave a limit, no number; the forecaster's own chance of this, stated with the estimate: 90%; the middle value does not contradict the limit.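

Compound 4 gives > 100000 nM in this assay, a limit of the assay and not a number. No step from compound 1 to compound 4 can be read, because both compounds sit at a limit and neither gives a number: the limit of > 100000 nM in this assay, at which 3 of the 4 values shown sit.

The compounds shown leave open whether nitro in place of trifluoromethyl weakens activity on the core of compound 1, as it does on the core shared by compound 2 and compound 3.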